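A few compounds are considered here, and "the series" means these few. Any claim that something is new, unique, unknown or untested is made for them only; others in the source may bear on it.

Working notes on the series, all read in a functional assay on Hep 3B2 cells (Homo sapiens) for inhibition, read by sulforhodamine B assay, with a stated time of 72 h; on this read-out lower numbers stand for stronger inhibition and higher numbers for weaker inhibition. Compound 1 `C[C@H](Nc1nc(N)nc(N)c1C#N)c1nn(-c2cccc(S(C)(=O)=O)c2)c2cc(F)ccc12` gives 19700 nM, the higher of the two actual numbers. Compound 3 `C[C@H](Nc1nc(N)nc(N)c1C#N)c1nn(-c2cccnc2)c2cc(C(F)(F)F)ccc12` gives 9710 nM, lower than compound 1 by a gap just beyond the scatter. Compound 2 `Cc1ccc2c(c1)c([C@H](C)Nc1ncnc3[nH]cnc13)nn2-c1cccnc1` returns only a limit, > 40000 nM.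

The next comparison pairs compound 1 with compound 4 `C[C@H](Nc1ncnc2[nH]cnc12)c1nn(-c2cccc(S(C)(=O)=O)c2)c2cc(F)ccc12`: a group of 9 heavy atoms (5 carbon, 4 nitrogen; one five-membered aromatic ring with 2 hetero atoms, one six-membered aromatic ring with 2 hetero atoms) in place of a group of 10 heavy atoms (5 carbon, 5 nitrogen; one six-membered aromatic ring with 2 hetero atoms), on an amine nitrogen. On the amine nitrogen, the 2,6-diamino-5-cyanopyrimidin-4-yl group gives way to a group with one five-membered and one six-membered aromatic ring, each with 2 hetero atoms. Going by the values given here, no measured pair isolates this change. The nearest guide is compound 2, which carries the same entering group and reads > 40000 nM, again a limit.

On that basis, the expected move is towards weaker inhibition, a higher number, with a real chance of only a limit being reported. The expected size is a 1.5-fold higher number from compound 1 to compound 4 (0.18 log units; within the scatter). For compound 4 the estimate is 30000 nM, with an expected range of 12000 nM to 70000 nM.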

Compound 4, half-maximal inhibitory concentration: 13000 nM
The estimate for compound 4 lay 2.3-fold (0.36 log units) above the measured number, within the range that was stated.
By their numbers in this assay, from the lowest: compounds 3, 4 and 1 (each within the scatter of the next, the first and the last beyond it). At a limit, above all of these: compound 2.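

In this assay, replacing the 2,6-diamino-5-cyanopyrimidin-4-yl group on the amine nitrogen gives a 1.5-fold lower number from compound 1 to compound 4 (0.18 log units; within the scatter), so this pair cannot be told apart at this position. The entering group, with its one five-membered and one six-membered aromatic ring, now has an actual number in compound 4, which shows that this group on the amine nitrogen does not by itself leave the read-out at a limit. Compound 2, which carries the same group on a different remainder of the molecule, stays a limit: the limit of > 40000 nM in this assay, at which 1 of the 4 values shown sits.

Still open, going by these compounds, is whether a simpler group on the amine nitrogen, such as a pyrimidine ring without the two amino groups and the nitrile, would read differently. Also open, on these data alone, is whether the same exchange gives a similar step in the trifluoromethyl-bearing compound 3.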